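This account rests on a few compounds, and the source may have more. Where it says the series, first, only, none or still open, it means among the compounds named here.

Measured in a functional assay on BT-483 cells (Homo sapiens) for cytotoxicity, read by MTT assay, with a stated time of 24 h; a lower number here means a stronger inhibitor, a higher number a weaker inhibitor:
- compound 1 `CCNc1cc(-c2ccc(NC(=O)Nc3ccc(C)cc3)cc2C)ccn1`: 22000 nM
- compound 2 `CCNc1cc(-c2ccc(NC(=O)Nc3ccc(C(F)(F)F)cc3)cc2C)ccn1`: 19700 nM
- compound 3 `CCNc1cc(-c2ccc(NC(=O)Nc3ccc(C)cc3)cc2C(F)(F)F)ccn1`: 27100 nM

Compound 3, at 27100 nM, has the highest of these three numbers, but it lies within the usual scatter of both other compounds, so the three cannot be ranked. The next compound, compound 4 `CCNc1cc(-c2ccc(NC(=O)Nc3cccc4ccccc34)cc2C(F)(F)F)ccn1`, keeps the rest of compound 3 and carries naphthalen-1-yl in place of 4-methylphenyl on an amide-type nitrogen.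

Two measured steps offer some guidance. The closer one is a 1.1-fold lower number from compound 1 to compound 2 (0.05 log units; within the scatter), which alters the 4-methylphenyl group that compound 4 loses. The other is a 1.2-fold higher number from compound 1 to compound 3 (0.09 log units; within the scatter), which makes the same kind of swap elsewhere in the molecule. Both lie within the scatter, so neither swap moved the number measurably. However, no measured pair replaces the whole 4-methylphenyl group, so these steps are only indirect evidence. With no measured sign of a direction, no step beyond the scatter is expected in this assay, although a surprise remains possible.

The expected change is a 1.2-fold lower number from compound 3 to compound 4 (0.09 log units; within the scatter), an estimate that carries no firm direction. For compound 4, the estimated value is 22000 nM, with an expected range of 10000 nM to 48000 nM.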

Compound 4, half-maximal inhibitory concentration: > 30000 nM
Compound 4 was reported as a limit (the forecaster's own chance of this, stated with the estimate: 10%); middle value at least 1.3-fold (0.13 log units) away from the limit.
By their numbers in this assay, from the lowest: compounds 2, 1 and 3 (each within the scatter of the next). At a limit, above all of these: compound 4.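

In this assay, compound 4 is reported only as a limit, > 30000 nM, and not as a number. This is the first change shown that replaces the whole 4-methylphenyl group on the amide-type nitrogen, and the step reads an at least 1.1-fold higher number from compound 3 to compound 4 (0.04 log units; that floor lies within the scatter). Adding a second aromatic ring at this place therefore gave no sign of a stronger inhibitor, but the floor of that step does not establish a real weakening, and the true size of the step stays unknown: the limit of > 30000 nM in this assay, at which 1 of the 4 values shown sits.

The compounds shown leave open whether any group on this nitrogen can bring the number clearly down, for instance a saturated cyclohexyl ring or a phenyl ring carrying an amine or a carboxylic acid in place of the methyl of 4-methylphenyl. They also leave open whether naphthalen-1-yl would give the same result on the core of compound 1, where a methyl stands in place of the trifluoromethyl that compound 3 and compound 4 share.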